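The source may hold more compounds than are shown below. What is called first, only, known or untested is meant among the compounds shown, and "the series" means these compounds.

Compound 1 `CC(C)C[C@]1(O)NC(=O)[C@]2(OC(Cc3ccccc3)=CC2=O)[C@H]1O` is a fused bicyclic lactam carrying a benzyl group on an unsaturated ring. In a functional assay on TE-8 cells (Homo sapiens) for cytotoxicity, read by WST assay, with a stated time of 48 h (a higher number here means a weaker inhibitor, a lower number a stronger inhibitor), compound 1 gives only a limit of the assay, > 100000 nM, so no number for it is known. Two related compounds appear beside it. Compound 2 `CC1=CC(=O)[C@]2(O[C@@H]2C(=O)CC(C)C)C(=O)N1` has no result in this assay, "not determined" (no result reported). Compound 3 `CC1=CC(=O)C2(OC2C(=O)CC(C)C)C(=O)N1` gives 21600 nM in this assay. Compound 2 and compound 3 are drawn with one difference between them: the fact that one of compounds 2 and 3 is drawn with a defined configuration and the other without, at the place where they differ. Compound 1 therefore stands at the weak end of what is shown, with the limit of > 100000 nM in this assay, at which 1 of the 3 values shown sits, the only thing known about it.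

Compound 4 `CC1=CC(=O)[C@]2(O1)C(=O)N[C@@](O)(CC(C)C)[C@@H]2O` keeps the core of compound 1 and changes a single group: hydrogen in place of phenyl on a saturated chain carbon bound to a double-bonded ring carbon. Among the compounds with values here, no pair of measured compounds shows the effect of such a change on this scaffold, so the size of the step is open. Since compound 1 sits at the limit, the step is expected to be small and to stay within the scatter, with the estimated shift from compound 1 to compound 4 being a number no higher from compound 1 to compound 4 (the limit leaves the size open). Compound 4 is expected to give about 100000 nM in this assay, in a range from 30000 nM to 300000 nM, with a real chance that only a limit is again reported.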

Compound 4, half-maximal inhibitory concentration: > 100000 nM
Compound 4: only a limit was reported; the forecaster's own chance of this, stated with the estimate: 60%; the middle value sits exactly at the limit.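

In this assay, within the data shown here, compound 1 and compound 4 each give only a limit and not a number, so no step between them can be read: the limit of > 100000 nM in this assay, at which 2 of the 4 values shown sit. The compounds shown leave open whether hydrogen in place of phenyl on a saturated chain carbon bound to a double-bonded ring carbon changes the activity of the shared core at all, and by how much.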